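Aminoquinazoline series: predicting a diethylaminoethyl variant

This account rests on a few compounds, and the source may have more. Where it says the series, first, only, none or still open, it means among the compounds named here.

Measured compounds:
- compound 1 `CCCCCNc1nc(NCc2ccco2)c2cc(F)ccc2n1`: 83.6%
- compound 2 `CCCCNc1nc(NCc2ccco2)c2cc(F)ccc2n1`: 75.4%
- compound 3 `COc1ccc(Nc2nc(NCc3ccco3)c3cc(F)ccc3n2)cc1`: 55.4%

In a functional assay on DU-145 cells (Homo sapiens) for cytotoxicity, read by MTT assay, with a stated time of 2 days, tested at 10 uM (a lower number here means less inhibition, a higher number more inhibition at the concentration tested (going by the name of the read-out)), compound 3 stands lowest of the three numbers; compound 2 is nearest, and compound 1 furthest, both beyond the scatter. The two steps that lead to compound 3 are a number 28.2 percentage points lower from compound 1 to compound 3 (beyond the scatter) and a number 20 percentage points lower from compound 2 to compound 3 (beyond the scatter), so replacing either alkyl chain on that nitrogen with 4-methoxyphenyl lowers the read-out by a modest amount. The step of a number 8.2 percentage points lower from compound 1 to compound 2 (within the scatter) is within the scatter.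

Compound 4 `CCN(CC)CCNc1nc(NCc2ccco2)c2cc(F)ccc2n1` differs from compound 3 by 2-(diethylamino)ethyl in place of 4-methoxyphenyl on a nitrogen on an aromatic ring.

Within the data shown here, no measured step covers an aminoalkyl chain on this nitrogen; the only bearing steps are those from the butyl and pentyl analogues, which both sit above compound 3 beyond the scatter. Among the measured compounds shown here, since the entering group is again a chain without a ring, and the aryl substituent is what set compound 3 apart, the expectation is that the number moves back upward, though the basic nitrogen in the chain has no precedent here and widens the range. Compound 4 is therefore expected to give 68% (range 45% to 90%), an estimated step of a number 12.6 percentage points higher from compound 3 to compound 4 (beyond the scatter).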

Compound 4, a percentage reported as inhibition, at one concentration (the size of the read-out at that concentration, not a potency): 26.6%
The estimate for compound 4 lay 41.4 percentage points above the measured number; the whole stated range lies above it.
By their numbers in this assay, from the lowest: compound 4; then compound 3; then compounds 2 and 1 (each within the scatter of the next).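

Working notes on the nitrogen on an aromatic ring: in this assay, having no ring in the entering group does not by itself restore the read-out, since 2-(diethylamino)ethyl in place of 4-methoxyphenyl gives a number 28.8 percentage points lower from compound 3 to compound 4 (beyond the scatter) and leaves compound 4 lowest of the four numbers. Against the plain chains the change is large in both comparisons, with a number 48.8 percentage points lower from compound 2 to compound 4 (beyond the scatter) and a number 57 percentage points lower from compound 1 to compound 4 (beyond the scatter), so the number is higher with an open chain at this position in the butyl and pentyl forms and lower in the form ending in diethylamino. This position therefore responds strongly to what the chain carries, which the earlier steps, all among butyl, pentyl and 4-methoxyphenyl, did not reveal, but nothing available explains the fall.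

Still open, on these data alone, is whether the low number belongs to the diethylamino end specifically or would also appear with a dimethylamino end, a morpholine ring or a hydroxyl group on the same chain. Also open, as far as these compounds go, is whether a longer chain such as hexyl, with no nitrogen in it, stays with the butyl and pentyl compounds in this assay.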